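The source may report more compounds than this note shows. Statements on the series, on what has been measured and on what is new or still open speak of the compounds shown alone.

Series notes. Compound 1 `Cc1nnc(SCC(=O)c2ccc(Cl)cc2)n1N1C(=O)c2ccccc2C1=O`, compound 2 `CSc1nnc(C)n1N1C(=O)c2ccccc2C1=O` and compound 3 `C#CCSc1nnc(CC)n1N1C(=O)c2ccccc2C1=O` share one core and differ at the chain bound to sulfur. In a functional assay on PC-3M cells (Homo sapiens) for cytotoxicity, read by MTT assay, with a stated time of 48 h (on this read-out higher numbers stand for weaker inhibition and lower numbers for stronger inhibition), compound 1 reaches only the limit > 200000 nM, not a number. Compound 2 likewise gives only the limit > 200000 nM. Compound 3 stands at the limit > 200000 nM, so its position is a bound, not a measured value. The step that the two limits leave unreadable from compound 1 to compound 2 is therefore unreadable. Compound 4 `CCOC(=O)CSc1nnc(CC)n1N1C(=O)c2ccccc2C1=O` differs from compound 3 by ethoxycarbonyl in place of ethynyl on a saturated chain carbon bound to a sulfur. For the measured compounds named here, no measured step bears on this change; the only evidence is the limit of > 200000 nM in this assay, at which 3 of the 3 values shown sit. The step that the limit leaves unreadable from compound 3 to compound 4 is expected to bring no shift beyond the scatter. Compound 4 is estimated at 300000 nM, within 100000 nM to 1000000 nM, most likely reported as a limit again.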

Compound 4, half-maximal inhibitory concentration: > 200000 nM
Compound 4: only a limit was reported; the forecaster's own chance of this, stated with the estimate: 85%; the middle value lies beyond the limit too.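

Compound 3 and compound 4 both give only a limit, so no step between them can be read: the limit of > 200000 nM in this assay, at which 4 of the 4 values shown sit.

The compounds shown leave open whether any chain bound to sulfur on the shared core gives a measurable value in this assay.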